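This account rests on a few compounds, and the source may have more. Where it says the series, first, only, none or still open, it means among the compounds named here.

Measured so far:
Compound 1 `Cc1cc(=O)n(-c2ccc(F)cc2)nc1C(=O)Nc1ccc(Oc2ncnc3[nH]ccc23)cc1` – > 60000 nM (a limit)
Compound 2 `Cc1cc(=O)n(-c2ccccc2OC(F)(F)F)nc1C(=O)Nc1ccc(Oc2ncnc3[nH]ccc23)cc1` – 22800 nM

Among the measured compounds shown here, in a functional assay on HepG2 cells (Homo sapiens) for cytotoxicity, read by MTT assay, with a stated time of 72 h (a higher number here means a weaker inhibitor, a lower number a stronger inhibitor), compound 2 at 22800 nM holds the only actual number. For compound 1 the reading > 60000 nM is a limit. Compound 3 `Cc1cc(=O)n(-c2cccc(C(F)(F)F)c2)nc1C(=O)Nc1ccc(Oc2ncnc3[nH]ccc23)cc1` carries 3-(trifluoromethyl)phenyl in place of 2-(trifluoromethoxy)phenyl on an aromatic nitrogen with the rest unchanged. For the measured compounds named here, the one measured step at this place is an at least 2.6-fold lower number from compound 1 to compound 2 (0.42 log units; beyond the scatter) and it is open-ended, so it sets no firm size for the change here. In this assay no shift beyond the scatter is expected, with a slight drift toward a higher number: the estimated step is a 1.3-fold higher number from compound 2 to compound 3 (0.12 log units; within the scatter) at most likely. Compound 3 is estimated at 30000 nM with an expected range from 12000 nM to 60000 nM overall.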

Compound 3, half-maximal inhibitory concentration: 9470 nM
Compound 3: the middle estimate sits 3.2-fold (0.50 log units) above what was measured; the measured number lies below the stated range.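

In this assay the step between two actual numbers at this position is a 2.4-fold lower number from compound 2 to compound 3 (0.38 log units; beyond the scatter), which gives this change a firm size that the earlier open-ended step could not. Across the three aryl groups, the largest shift is an at least 6.3-fold lower number from compound 1 to compound 3 (0.80 log units; beyond the scatter), and it too remains open-ended. Compound 1 remains a limit: the limit of > 60000 nM in this assay, at which 1 of the 3 values shown sits.

3-(trifluoromethyl)phenyl and 2-(trifluoromethoxy)phenyl differ both in the group and in where it sits on the phenyl ring, and the compounds shown do not separate the two. They also leave open how a phenyl carrying an amine or a carboxylic acid would read here.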